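The source may report more compounds than this note shows. Statements on the series, on what has been measured and on what is new or still open speak of the compounds shown alone.

Compound 1 `C[C@H]1[C@H](NCc2cncnc2)C[C@H]2C[C@@H]1C2(C)C` carries a pyrimidin-5-yl group on the saturated chain carbon bound to the amine nitrogen of the shared core. In an ADME assay on MDCK cells (Canis lupus familiaris) for cytotoxicity, read by microscopy, with a stated time of 48 h (on this read-out higher numbers stand for lower toxicity in this test and lower numbers for higher toxicity in this test), compound 1 gives only a limit, > 100000 nM, and no number. Two thiophene analogues stand beside it: compound 2 `C=Cc1ccsc1CN[C@@H]1C[C@H]2C[C@@H]([C@H]1C)C2(C)C`, which in this assay gives 50000 nM, and compound 3 `CCOc1ccsc1CN[C@@H]1C[C@H]2C[C@@H]([C@H]1C)C2(C)C`, which in this assay gives 50000 nM. Going by the values given here, the one measured step, no change at the digits printed from compound 2 to compound 3 (within the scatter), concerns a substituent on the thiophene ring rather than the exchange of the aromatic ring itself, so it bears only loosely on the step considered here. Compound 4 `Cc1csc(CN[C@@H]2C[C@H]3C[C@@H]([C@H]2C)C3(C)C)c1` differs from compound 1 by 4-methylthiophen-2-yl in place of pyrimidin-5-yl on a saturated chain carbon bound to an amine nitrogen. Among the compounds with values here, no measured pair exchanges pyrimidin-5-yl for a thiophene. Compound 1 sits at the limit (the limit of > 100000 nM in this assay, at which 1 of the 3 values shown sits). Compound 2 and compound 3, by contrast, each sit at a finite value. Compound 4 is therefore expected to lie near those two, a step of an at least 1.6-fold lower number from compound 1 to compound 4 (0.22 log units; that floor lies within the scatter) that cannot be sized against a limit. The estimate for compound 4 is 60000 nM, within 25000 nM to 150000 nM.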

Compound 4, minimum cytotoxic concentration: 12500 nM
The estimate for compound 4 lay 4.8-fold (0.68 log units) above the measured number; measured number outside the range, below it.
By their numbers in this assay, from the lowest: compound 4; then compounds 2 and 3 (each within the scatter of the next). At a limit, above all of these: compound 1.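

In this assay, the exchange of the aromatic ring itself on a saturated chain carbon bound to an amine nitrogen now has a measured size: 4-methylthiophen-2-yl in place of pyrimidin-5-yl gives an at least 8.0-fold lower number from compound 1 to compound 4 (0.90 log units; beyond the scatter), which means higher toxicity in this test. The earlier step concerned only a substituent on the thiophene ring and stayed within the scatter, so it did not show that this place responds to a change of ring. The size of the new step is only a floor, because compound 1 stands at a limit and not at a number: the limit of > 100000 nM in this assay, at which 1 of the 4 values shown sits.

Going by these compounds, whether the thiophene ring or its methyl group carries the step stays open. So does how a phenyl or pyridin-3-yl group would read on the same carbon.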